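The compounds below may be only part of what the source reports. "The series", "measured", "known", "first", "only" and "open" are said of these compounds alone.

This account concerns a small set of compounds sharing one core and differing only in the aromatic group attached to it. Compound 1 `COC(=O)c1sc2cc(-c3ccsc3)cnc2c1N` gives 12700 nM in a functional assay on MCF7 cells (Homo sapiens) for inhibition, read by sulforhodamine B assay, with a stated time of 48 h; on this read-out lower numbers stand for stronger inhibition of growth and higher numbers for weaker inhibition of growth. Compound 2 `COC(=O)c1sc2cc(-c3cccs3)cnc2c1N` gives 26900 nM in this assay. For compound 3 `COC(=O)c1sc2cc(-c3cccnc3)cnc2c1N` the result in this assay is a limit of the assay, > 112000 nM. Compound 3 thus stands at the weak end of the three, at the limit of > 112000 nM in this assay, at which 1 of the 3 values shown sits. The measured steps were a 2.1-fold higher number from compound 1 to compound 2 (0.33 log units; beyond the scatter), an at least 8.8-fold higher number from compound 1 to compound 3 (0.94 log units; beyond the scatter) and an at least 4.1-fold higher number from compound 2 to compound 3 (0.61 log units; beyond the scatter), each beyond the scatter.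

Compound 4 `COC(=O)c1sc2cc(-c3ccccc3N)cnc2c1N` has not yet been measured. It differs from compound 3 by 2-aminophenyl in place of pyridin-3-yl on an aromatic carbon. Among the measured compounds shown here, no measured step exchanges a pyridin-3-yl for a 2-aminophenyl, so the bearing of the measured steps is indirect: the two steps that end at compound 3 show that pyridin-3-yl gives the weakest result among the measured groups, and a move away from it may recover part of that difference. The step from compound 3 is therefore expected to be an at least 3.7-fold lower number from compound 3 to compound 4 (0.57 log units; beyond the scatter), toward a lower number, though with wide uncertainty. Compound 4 is expected to give about 30000 nM in this assay, somewhere between 7000 nM and 150000 nM.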

Compound 4, concentration for 50% growth inhibition: 4200 nM
Estimate against measurement, compound 4: 7.1-fold (0.85 log units) above, and the stated range ends above it.
By their numbers in this assay, from the lowest: compound 4; then compound 1; then compound 2. At a limit, above all of these: compound 3.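

At this position, on an aromatic carbon two atoms from the ring nitrogen, 2-aminophenyl gives the lowest number of the four compounds in this assay, with a 3.0-fold lower number from compound 1 to compound 4 (0.48 log units; beyond the scatter) and a 6.4-fold lower number from compound 2 to compound 4 (0.81 log units; beyond the scatter), so both thiophene groups are now surpassed. Among the earlier compounds, only compound 3 carried a six-membered aromatic ring, and the change to compound 4, an at least 26-fold lower number from compound 3 to compound 4 (1.42 log units; beyond the scatter), shows that a six-membered aromatic ring here need not leave the number high. This large step is only a bound, as compound 3 stands at a limit of the assay: the limit of > 112000 nM in this assay, at which 1 of the 4 values shown sits.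

The compounds shown leave open how much of the result belongs to the amine and how much to the carbon-only ring, a question a plain phenyl group would address, and whether the amine's place on that ring matters, as 3-aminophenyl or 4-aminophenyl would show. They also leave open whether a hydroxyl, a methoxy group or an acetylated amine could stand in for the amine at this position.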